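This account rests on a few compounds, and the source may have more. Where it says the series, first, only, none or still open, it means among the compounds named here.

In a functional assay on BXPC-3 cells (Homo sapiens) for antiproliferative activity, read by sulforhodamine B assay, with a stated time of 72 h (a higher number here means a weaker inhibitor, a lower number a stronger inhibitor), compound 3 `C=CCSc1ccc2c3c(cccc13)C1=NC(=O)C(C(=O)OCC(=O)SCCC)=C12` gives 13700 nM and stands level with compound 1 `C=CCOC(=O)C1=C2C(=NC1=O)c1cccc3c(SCCC)ccc2c13` at 12900 nM on this measure. Compound 2 `CCCSc1ccc2c3c(cccc13)C1=NC(=O)C(C(=O)OCC)=C12` gives 5800 nM as the lowest number of the three. Compound 4 `CCCSC(=O)COC(=O)C1=C2C(=NC1=O)c1cccc3c(SCCC)ccc2c13` differs from compound 3 at one place: ethyl in place of vinyl on a saturated chain carbon bound to a sulfur in words, ethyl in place of vinyl on a saturated chain carbon bound to a sulfur, or allylsulfanyl to propylsulfanyl. Within the data shown here, no measured pair makes this change on the sulfur chain itself. The nearest guide is a 2.2-fold lower number from compound 1 to compound 2 (0.35 log units; beyond the scatter) where a vinyl group also leaves, but on a saturated chain carbon bound to an oxygen next to a carbonyl group. Going by that modest step to compound 2 and its different place, only a small fall in the number is expected in this assay and perhaps nothing beyond the scatter. The expected change is a 1.4-fold lower number from compound 3 to compound 4 (0.14 log units; within the scatter) on this estimate. For compound 4 the estimated value is 10000 nM with an expected range from 5000 nM to 20000 nM around it.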

Compound 4, half-maximal inhibitory concentration: 56300 nM
Compound 4: middle estimate off by 5.6-fold (0.75 log units), on the low side; the measured number lies above the stated range.
By their numbers in this assay, from the lowest: compound 2; then compounds 1 and 3 (each within the scatter of the next); then compound 4.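

In this assay, losing the vinyl is not a neutral edit on the sulfur chain: allylsulfanyl to propylsulfanyl raises the number (a 4.1-fold higher number from compound 3 to compound 4 (0.61 log units; beyond the scatter)). Among these compounds, this runs opposite to the only other step in which a vinyl leaves, on a saturated chain carbon bound to an oxygen next to a carbonyl group (a 2.2-fold lower number from compound 1 to compound 2 (0.35 log units; beyond the scatter)), so the two places do not respond alike. At that oxygen-side place, (propylsulfanyl)carbonyl also goes with a higher number, whether it replaces methyl (a 9.7-fold higher number from compound 2 to compound 4 (0.99 log units; beyond the scatter)) or vinyl (a 4.4-fold higher number from compound 1 to compound 4 (0.64 log units; beyond the scatter)), leaving compound 4 with the highest number of the four.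

From the compounds shown here alone, whether a longer chain or an amine on the sulfur would push the number further up or bring it back down remains open. Nothing available explains why the number rises at either place.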